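The source may hold more compounds than are shown below. What is called first, only, known or untested is meant among the compounds shown, and "the series" means these compounds.

Compound 1, `Cc1ccccc1-c1cc(C(=O)NCCCN2CCCCC2)c2cn[nH]c2n1`, in an assay on isolated protein for inhibition of N-lysine methyltransferase SMYD2 (Homo sapiens) (on this read-out higher numbers stand for weaker inhibition and lower numbers for stronger inhibition), gives 13500 nM.
Compound 2, `O=C(NCCCN1CCCC1)c1cc(-c2ccccc2Cl)nc2[nH]ncc12`, in this assay gives 8000 nM.

Among the compounds with values here, compound 2 holds the lowest of the two numbers measured so far; the nearest is compound 1, whose number is higher by a margin that falls within the usual scatter of such measurements, so the two cannot be ranked against each other. Within the data shown here, they differ in more than one place at once, the group on the phenyl ring and the saturated amine ring at the end of the chain, and no single step between them is given, so only their two values can be set side by side.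

Compound 3, `CCc1ccccc1-c1cc(C(=O)NCCCN2CCCC2)c2cn[nH]c2n1`, has not yet been measured in this assay. Relative to compound 2 it carries ethyl in place of chloro on an aromatic carbon, that is, ethyl in place of chloro on an aromatic carbon. Among the measured compounds shown here, no measured step covers this exchange. For the measured compounds named here, the only guidance is that compound 1, carrying methyl where compound 2 carries chloro, sits within the scatter of compound 2, which suggests the exchange for ethyl is unlikely to move the number far. Compound 3 is therefore expected to land close to compound 2, with a 1.3-fold higher number from compound 2 to compound 3 (0.10 log units; within the scatter) as the expected step, no larger than the scatter in either direction. The estimate for compound 3 is 10000 nM, within a range from 3000 nM to 30000 nM.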

Compound 3, half-maximal inhibitory concentration: 8400 nM
Estimate against measurement, compound 3: 1.2-fold (0.08 log units) above; measured number inside the range.
By their numbers in this assay, from the lowest: compounds 2, 3 and 1 (each within the scatter of the next).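

Until now, the group on the phenyl ring could not be read on its own, since compound 1 and compound 2 also differ in their amine ring. With that ring held the same, the exchange from 2-chlorophenyl to 2-ethylphenyl in this assay gives a 1.1-fold higher number from compound 2 to compound 3 (0.02 log units; within the scatter) and so leaves compound 2 and compound 3 indistinguishable, even though one chlorine atom leaves and two carbon atoms enter at a place ortho to a large group. So, for this one pair, replacing chloro with the slightly larger ethyl does not produce a readable change in the number, and no measurement available here offers an explanation for that.

One pair cannot show how far this tolerance extends: a longer chain such as butyl, or a group of a different kind such as an amine or a carboxylic acid, could behave quite differently at this place. On these data alone, it also remains open whether a phenyl ring with only hydrogen at this place would give a number close to those of compound 2 and compound 3, or whether some group is needed there at all.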